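The source may hold more compounds than are shown below. What is called first, only, known or untested is meant among the compounds shown, and "the series" means these compounds.

Working notes on the series. Among the measured compounds shown here, compound 3 `O=C(/C=C/c1cccc(NS(=O)(=O)c2cccc(Cl)c2)c1)c1nc2ccccc2[nH]1` gives 737 nM in a functional assay on HCT-116 cells (Homo sapiens) for antiproliferative activity, read by MTT assay, with a stated time of 48 h (a lower number here means a stronger inhibitor, a higher number a weaker inhibitor), the lowest of the three numbers so far; compound 1 `O=C(/C=C/c1cccc(NC(=O)c2ccccc2Cl)c1)c1nc2ccccc2[nH]1` gives 1280 nM and compound 2 `O=C(Nc1cccc(/C=C/C(=O)c2nc3ccccc3[nH]2)c1)c1cccc(Br)c1` gives 1560 nM. The gap a 1.7-fold lower number from compound 1 to compound 3 (0.24 log units; within the scatter) stays within the scatter, while a 2.1-fold lower number from compound 2 to compound 3 (0.33 log units; beyond the scatter) just clears it. Compound 4 `Cc1cc(C)cc(S(=O)(=O)Nc2cccc(/C=C/C(=O)c3nc4ccccc4[nH]3)c2)c1` carries 3,5-dimethylphenyl in place of 3-chlorophenyl on a sulfonyl sulfur. For the measured compounds named here, no measured step exchanges the aryl group on the sulfonyl sulfur; the nearest precedent, an aryl swap on a carbonyl carbon, gave a 1.2-fold higher number from compound 1 to compound 2 (0.09 log units; within the scatter), within the scatter. The expectation for this assay is therefore no step beyond the scatter, a 1.1-fold higher number from compound 3 to compound 4 (0.04 log units; within the scatter). Compound 4 is estimated at 800 nM, with a range from 350 nM to 1900 nM.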

Compound 4, half-maximal inhibitory concentration: 1220 nM
The estimate for compound 4 lay 1.5-fold (0.18 log units) below the measured number; measured number inside the range.
By their numbers in this assay, from the lowest: compounds 3, 4, 1 and 2 (each within the scatter of the next, the first and the last beyond it).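

Among the compounds shown here, this is the first measured exchange of the aryl group on a sulfonyl sulfur: 3,5-dimethylphenyl in place of 3-chlorophenyl gives a 1.7-fold higher number from compound 3 to compound 4 (0.22 log units; within the scatter), so a ring carrying only carbon substituents stands within the scatter of the chlorine-bearing ring at this position. That reading rests on this single pair, and no measurement at hand accounts for the step. Still open, going by these compounds, is whether an aryl group carrying an amine or a carboxylic acid, or a longer chain in place of the aryl group on the sulfonyl sulfur, would also stay within the scatter.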